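Aryl replacement and cytotoxicity across a shared core

The source may report more compounds than this note shows. Statements on the series, on what has been measured and on what is new or still open speak of the compounds shown alone.

Measured so far:
compound 1 `Cc1ccc(/C=C/c2nnc(-c3ccc4c(c3)OCCO4)o2)cc1` — 265000 nM
compound 2 `Clc1ccccc1/C=C/c1nnc(-c2ccc3c(c2)OCCO3)o1` — 368000 nM
compound 3 `Clc1ccc(/C=C/c2nnc(-c3ccc4c(c3)OCCO4)o2)cc1` — 312000 nM

In an ADME assay on HUVEC cells (Homo sapiens) for cytotoxicity, read by MTT assay, with a stated time of 24 h (on this read-out lower numbers stand for higher toxicity in this test and higher numbers for lower toxicity in this test), compound 1 gives the lowest of the three numbers; the nearest is a 1.2-fold higher number from compound 1 to compound 3 (0.07 log units; within the scatter) and the furthest is a 1.4-fold higher number from compound 1 to compound 2 (0.14 log units; within the scatter), so all three lie within the scatter of one another.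

Compound 4 `COc1cccc(/C=C/c2nnc(-c3ccc4c(c3)OCCO4)o2)c1` differs from compound 1 by 3-methoxyphenyl in place of 4-methylphenyl on a double-bonded chain carbon bound to a double-bonded chain carbon. Among the measured compounds shown here, the steps that bear on it are those that also swap the aryl group on the double-bonded chain carbon: a 1.4-fold higher number from compound 1 to compound 2 (0.14 log units; within the scatter), a 1.2-fold higher number from compound 1 to compound 3 (0.07 log units; within the scatter) and a 1.2-fold lower number from compound 2 to compound 3 (0.07 log units; within the scatter), none beyond the scatter. No step beyond the scatter is therefore expected, and a 1.1-fold higher number from compound 1 to compound 4 (0.02 log units; within the scatter) is the estimated outcome. Compound 4 is expected to give 280000 nM, in the range 150000 nM to 520000 nM.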

Compound 4, half-maximal cytotoxic concentration: 332000 nM
Compound 4: middle estimate off by 1.2-fold (0.07 log units), on the low side; the measured number falls inside the stated range.
By their numbers in this assay, from the lowest: compounds 1, 3, 4 and 2 (each within the scatter of the next).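

In this assay the 3-methoxyphenyl group, which brings an oxygen and a hydrogen-bond acceptor to a place where the earlier aryl groups have neither, stays within the scatter of all three earlier compounds (a 1.3-fold higher number from compound 1 to compound 4 (0.10 log units; within the scatter); a 1.1-fold higher number from compound 3 to compound 4 (0.03 log units; within the scatter); a 1.1-fold lower number from compound 2 to compound 4 (0.04 log units; within the scatter)). At this place on the double-bonded chain carbon, the four aryl groups shown therefore cannot be told apart by this read-out. No supporting data explain this result.

As far as these compounds go, whether an amine or a carboxylic acid on the aryl ring would give a step beyond the scatter stays open. So does the outcome of any change to the shared core.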